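A few compounds are considered here, and "the series" means these few. Any claim that something is new, unique, unknown or untested is made for them only; others in the source may bear on it.

Compound 1 `CCC(CC)(c1nnc[nH]1)c1ccc(-c2ccc3cc(F)cc(F)c3c2)[nH]c1=O`: 89 nM
Compound 2 `CC(C)C(Cc1ncc[nH]1)c1ccc(-c2ccc3cccc(F)c3c2)[nH]c1=O`: 11 nM
Compound 3 `CC(C)C(O)(C(=O)O)c1ccc(-c2ccc3ccccc3c2)[nH]c1=O`: 544 nM

Of the compounds shown here, three have been tested in an assay on CHO cells for displacement of a labelled ligand from prostaglandin E2 receptor EP3 subtype (Homo sapiens), read by radioligand binding; on this read-out lower numbers stand for stronger inhibition and higher numbers for weaker inhibition. In this assay compound 1 gives 89 nM, compound 2 gives 11 nM and compound 3 gives 544 nM. Compound 2 stands at the lowest number of the three; its gap to compound 1 and its larger gap to compound 3 both lie beyond the usual scatter, so compound 2 is the strongest binder among them. No two of these compounds differ in only one place, so no single step can be read from the measured set.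

Compound 4 `CC(C)C(Cc1nnc[nH]1)c1ccc(-c2ccc3cccc(F)c3c2)[nH]c1=O` has not been measured. It differs from compound 2 by 4H-1,2,4-triazol-3-yl in place of 1H-imidazol-2-yl on a saturated chain carbon, two bonds along the chain from an aromatic carbon. The entering ring appears in compound 1, which gives 89 nM in this assay but differs from compound 4 in several other places, so it offers only a loose hint. The step expected from this change is a 1.8-fold higher number from compound 2 to compound 4 (0.26 log units; within the scatter), a small move toward weaker binding that may stay within the scatter. Compound 4 is expected to give about 20 nM in this assay, within a range from 6 nM to 65 nM.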

Compound 4, inhibition constant: 10 nM
Estimate against measurement, compound 4: 2.0-fold (0.30 log units) above, within the range that was stated.
By their numbers in this assay, from the lowest: compounds 4 and 2 (each within the scatter of the next); then compound 1; then compound 3.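

In this assay, for the compounds shown here, 4H-1,2,4-triazol-3-yl in place of 1H-imidazol-2-yl on a saturated chain carbon, two bonds along the chain from an aromatic carbon, gives a 1.1-fold lower number from compound 2 to compound 4 (0.04 log units; within the scatter), and this is the first step in the set that can be read at a single place. This read-out does not separate the two rings at this position, although the entering ring has 3 hetero atoms rather than 2 and 2 hydrogen-bond acceptors rather than 1. The earlier compounds shown here could not show this, since no two of them differed in only one place.

As far as these compounds go, whether an amine in place of either ring, or a longer chain carrying the 4H-1,2,4-triazol-3-yl ring, would read alike remains open. No measurement shown here accounts for the result.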